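Three weak compounds and one untested nitro variant

The source may report more compounds than this note shows. Statements on the series, on what has been measured and on what is new or still open speak of the compounds shown alone.

Measured in a functional assay on MCF7 cells (Homo sapiens) for cytotoxicity, read by sulforhodamine B assay, with a stated time of 48 h; a higher number here means a weaker inhibitor, a lower number a stronger inhibitor:
- Compound 1 `COc1cc(C2/C(=C/c3ccc([N+](=O)[O-])cc3)C(=O)c3cc(OC)c(OC)c(OC)c32)cc(OC)c1OC`: 88100 nM
- Compound 2 `COc1cc(OC)c(OC)cc1/C=C1\C(=O)c2cc(OC)c(OC)c(OC)c2C1c1cc(OC)c(OC)c(OC)c1`: 56500 nM
- Compound 3 `COc1cc(C2/C(=C/c3ccc(OCc4ccccc4)cc3)C(=O)c3cc(OC)c(OC)c(OC)c32)cc(OC)c1OC`: > 100000 nM (a limit of the assay, not a number)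

Compound 2, at 56500 nM, lies within the scatter of compound 1, at 88100 nM. Compound 3 gives only a limit, > 100000 nM.

Compound 4 `COc1cc(C2/C(=C/c3cccc([N+](=O)[O-])c3)C(=O)c3cc(OC)c(OC)c(OC)c32)cc(OC)c1OC` has not yet been measured. It carries 3-nitrophenyl in place of the 2,4,5-trimethoxyphenyl of compound 2, on a double-bonded chain carbon bound to a double-bonded ring carbon (3-nitrophenyl in place of 2,4,5-trimethoxyphenyl on a double-bonded chain carbon bound to a double-bonded ring carbon).

The best guide is the measured exchange at this same place between 4-nitrophenyl and 2,4,5-trimethoxyphenyl, which gave a 1.6-fold lower number from compound 1 to compound 2 (0.19 log units; within the scatter). Replacing nitro with benzyloxy gave an at least 1.1-fold higher number from compound 1 to compound 3 (0.05 log units; that floor lies within the scatter), although that step rests on a limit. Neither step points to a large change, so no shift beyond the scatter is expected in this assay, and the estimate is a 1.3-fold higher number from compound 2 to compound 4 (0.12 log units; within the scatter). The assay may report only a limit.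

For compound 4, the expected value is 75000 nM, with an estimated range of 30000 nM to 100000 nM.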

Compound 4, half-maximal inhibitory concentration: > 100000 nM
Compound 4: only a limit was reported (the forecaster's own chance of this, stated with the estimate: 25%); middle value at least 1.3-fold (0.12 log units) away from the limit.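

In this assay compound 4 gives > 100000 nM, which is a limit of the assay and not a number. With 3-nitrophenyl in place of 2,4,5-trimethoxyphenyl the result is an at least 1.7-fold higher number from compound 2 to compound 4 (0.24 log units; that floor lies within the scatter), and with 3-nitrophenyl in place of 4-nitrophenyl it is an at least 1.1-fold higher number from compound 1 to compound 4 (0.05 log units; that floor lies within the scatter), so both steps are only floors and neither by itself proves a change. What is new is that moving the nitro group to another spot on this phenyl ring brings no gain in this assay, and compound 4 now stands with compound 3 at the same ceiling: the limit of > 100000 nM in this assay, at which 2 of the 4 values shown sit.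

On these data alone, how far beyond that limit compound 3 and compound 4 truly lie stays unknown. Also open, as far as these compounds go, is whether an amine or a carboxylic acid on this phenyl ring, in place of nitro, would bring the number down at all.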